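This account rests on a few compounds, and the source may have more. Where it says the series, first, only, none or still open, it means among the compounds named here.

Working notes on the dithiocarbamate series. Compound 3 `O=c1c(CSC(=S)N2CCOCC2)coc2ccccc12` is the unsubstituted member; in a functional assay on MDA-MB-435S cells (Homo sapiens) for antiproliferative activity, read by MTT assay, with a stated time of 72 h (on this read-out lower numbers stand for stronger inhibition and higher numbers for weaker inhibition), compound 3 gives 3900 nM, the highest number among the three measured compounds. Compound 2 `O=c1c(CSC(=S)N2CCOCC2)coc2cc(Cl)ccc12`, which carries chloro on the aromatic carbon, gives 600 nM, and compound 1 `Cc1ccc2c(=O)c(CSC(=S)N3CCCCC3)coc2c1`, which carries methyl but a different amine on the dithiocarbamate, gives 1700 nM.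

The next compound is compound 4 `Cc1ccc2c(=O)c(CSC(=S)N3CCOCC3)coc2c1`. Relative to compound 3 the change is methyl in place of hydrogen on an aromatic carbon. Going by the values given here, the only measured step at the same position is the loss of chloro, a 6.5-fold higher number from compound 2 to compound 3 (0.81 log units; beyond the scatter), a modest change and beyond the scatter; it shows that a substituent at this carbon lowers the number. Among the compounds with values here, no measured pair isolates methyl against hydrogen on the shared core; compound 1 and compound 3 differ in two places, so their values can only be read side by side, and the methyl-bearing compound 1 shows the lower number.

On this basis a lower number is expected for compound 4, by a step estimated at a 3.0-fold lower number from compound 3 to compound 4 (0.48 log units; beyond the scatter), smaller than that seen for chloro. The estimate for compound 4 in this assay is 1300 nM, with a range from 500 nM to 3200 nM.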

Compound 4, half-maximal inhibitory concentration: 5500 nM
Compound 4: the middle estimate sits 4.2-fold (0.63 log units) below what was measured; measured number above the stated range.
By their numbers in this assay, from the lowest: compound 2; then compound 1; then compounds 3 and 4 (each within the scatter of the next).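

In this assay, going by these compounds alone, methyl in place of hydrogen on this aromatic carbon gives a 1.4-fold higher number from compound 3 to compound 4 (0.15 log units; within the scatter) and so does not separate the two groups, which no earlier pair could test. The earlier step from chloro to hydrogen therefore does not extend to every substituent here: methyl in place of chloro gives a 9.2-fold higher number from compound 2 to compound 4 (0.96 log units; beyond the scatter) at the same carbon, so among the three groups seen at this carbon only chloro goes with the lower number. The amine on the dithiocarbamate now also reads as a single change, with morpholin-4-yl in place of piperidin-1-yl on the thiocarbonyl carbon giving a 3.2-fold higher number from compound 1 to compound 4 (0.51 log units; beyond the scatter) on a core that carries methyl, so the lower number of compound 1 goes with piperidin-1-yl and not with methyl. No measurement at hand gives a reason for any of these steps.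

From the compounds shown here alone, it remains open whether other groups on this aromatic carbon, such as fluoro, bromo, methoxy or a longer chain like ethyl, follow chloro or follow methyl and hydrogen. Also open, going by these compounds, are whether chloro and piperidin-1-yl together go beyond either change alone, and how other amines on the thiocarbonyl carbon, such as pyrrolidin-1-yl or diethylamino, compare.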